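Ethynyl for benzofuranyl on the shared core

This account rests on a few compounds, and the source may have more. Where it says the series, first, only, none or still open, it means among the compounds named here.

Measured in an ADME assay on BJ cells (Homo sapiens), read by MTT assay, with a stated time of 72 h; on this read-out higher numbers stand for weaker inhibition and lower numbers for stronger inhibition:
- Compound 1 `C#Cc1cn([C@@H]2O[C@H](CO)[C@@H](O)[C@H]2O)c2ncnc(OC)c12`: 98400 nM
- Compound 2 `CN(C)c1ncnc2c1c(-c1cc3ccccc3o1)cn2[C@@H]1O[C@H](CO)[C@@H](O)[C@H]1O`: > 100000 nM

The entry for compound 2, > 100000 nM, is a limit of the assay and not a number. Compound 3 `C#Cc1cn([C@@H]2O[C@H](CO)[C@@H](O)[C@H]2O)c2ncnc(N(C)C)c12` is still unmeasured. The change from compound 2 is ethynyl in place of 1-benzofuran-2-yl on an aromatic carbon. Within the data shown here, no measured step covers this change. Among the measured compounds shown here, the only guide is compound 1, which also carries ethynyl, at 98400 nM. A modest move towards stronger inhibition in this assay is therefore expected, and the expected size is an at least 1.4-fold lower number from compound 2 to compound 3 (0.15 log units; that floor lies within the scatter). Compound 3 is expected at 70000 nM, with an estimated range of 20000 nM to 100000 nM.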

Compound 3, half-maximal inhibitory concentration: 410 nM
The estimate for compound 3 lay 170-fold (2.23 log units) above the measured number, outside the stated range (below it).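

In this assay, the position on the five-membered aromatic ring proves highly sensitive with dimethylamino on the shared core: ethynyl in place of 1-benzofuran-2-yl gives an at least 240-fold lower number from compound 2 to compound 3 (2.38 log units; beyond the scatter). Compound 2 stands at a limit of the assay and not a number, which makes that step only a floor: the limit of > 100000 nM in this assay, at which 1 of the 3 values shown sits. With ethynyl held constant, dimethylamino in place of methoxy gives a 240-fold lower number from compound 1 to compound 3 (2.38 log units; beyond the scatter), so the second place also carries a large step.

Open, on these data alone, is whether ethyl or nitrile at the ethynyl position would keep this strong inhibition. Also open, as far as these compounds go, is whether methylamino or an unsubstituted amine could replace dimethylamino.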